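The source may report more compounds than this note shows. Statements on the series, on what has been measured and on what is new or still open speak of the compounds shown alone.

Measured so far in a functional assay on THP-1 cells (Homo sapiens) for inhibition, read by ELISA, with stated times of 2 h and 48 h; a lower number here means a stronger inhibitor, a higher number a weaker inhibitor:

- Compound 1 `[O-]/[N+](=C\c1cn(CCC(F)(F)C(F)(F)C(F)(F)C(F)(F)C(F)(F)C(F)(F)F)nn1)Cc1ccccc1`: 12100 nM
- Compound 2 `[O-]/[N+](=C\c1cn(CCC(F)(F)C(F)(F)C(F)(F)C(F)(F)C(F)(F)C(F)(F)C(F)(F)C(F)(F)F)nn1)Cc1ccccc1`: 17000 nM

For the measured compounds named here, compound 1 cannot be set apart from compound 2 on these numbers, as the only measured step, a 1.4-fold higher number from compound 1 to compound 2 (0.15 log units; within the scatter), lies within the scatter. That step swaps fluoro for 1,1,2,2,2-pentafluoroethyl on a saturated chain carbon.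

Compound 3 `CC(C)(C)/[N+]([O-])=C/c1cn(CCC(F)(F)C(F)(F)C(F)(F)C(F)(F)C(F)(F)C(F)(F)F)nn1` has not yet been measured. It keeps the shared core and fluorinated chain of compound 1 but carries tert-butyl in place of benzyl on a double-bonded nitrogen. The six-membered aromatic ring of carbon only thus leaves the molecule.

The measured step bears on this change only indirectly, since it concerns the chain and leaves the group on the nitrogen untouched. Going by the values given here, no measured compound shows what such a swap does in this assay, so no direction can be expected from the data. The expected step, a 1.2-fold higher number from compound 1 to compound 3 (0.06 log units; within the scatter), is therefore none beyond the scatter, although the uncertainty is wide. For compound 3 the estimated value is 14000 nM, with an expected range of 5000 nM to 40000 nM.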

Compound 3, half-maximal inhibitory concentration: 8100 nM
Beside the measured number, compound 3's estimate is 1.7-fold (0.24 log units) above it, and the stated range covers the measured number.
By their numbers in this assay, from the lowest: compounds 3, 1 and 2 (each within the scatter of the next, the first and the last beyond it).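

For the compounds shown here, compound 3 gives the first reading at the double-bonded nitrogen, as the earlier step touched only the fluorinated chain: in this assay, tert-butyl in place of benzyl gives a 1.5-fold lower number from compound 1 to compound 3 (0.17 log units; within the scatter). The six-membered aromatic ring of carbon only leaves with benzyl, and the number stays within the scatter, so this pair shows that the ring is not needed for a reading of the same size in this assay, and it sets neither compound ahead of the other. Nothing available explains why the two groups read alike.

The compounds shown leave open whether other groups on that nitrogen, such as cyclohexyl, phenyl or a longer chain ending in an amine, would read apart from benzyl and tert-butyl. They also leave open whether the swap would read the same way on a different chain, such as a shorter fluorinated chain or a plain hexyl chain, as tert-butyl appears here only with the fluorinated chain of compound 1.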